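Extending the Amine Linker on a Piperidine Carbon

A few compounds are considered here, and "the series" means these few. Any claim that something is new, unique, unknown or untested is made for them only; others in the source may bear on it.

Measured compounds:
compound 1: `c1ccc(C2CCCCN2C2CCN(CCCc3c[nH]c4ccc(-n5cnnc5)cc34)CC2)cc1`, 1.9 nM
compound 2: `c1ccc2c(c1)CCC2NC1CCN(CCCc2c[nH]c3ccc(-n4cnnc4)cc23)CC1`, 8.9 nM

In an assay on CHO cells for displacement of a labelled ligand from 5-hydroxytryptamine receptor 1D (Homo sapiens) (on this read-out lower numbers stand for stronger inhibition and higher numbers for weaker inhibition), compound 1 gives 1.9 nM, while compound 2 gives 8.9 nM. Going by the values given here, compound 2 therefore stands as the higher of the two numbers, and its only neighbour, compound 1, sits well below it, beyond the usual scatter.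

Compound 3 is `c1ccc2c(c1)CCC2NCC1CCN(CCCc2c[nH]c3ccc(-n4cnnc4)cc23)CC1`. It differs from compound 2 in one place: ((2,3-dihydro-1H-inden-1-yl)amino)methyl in place of (2,3-dihydro-1H-inden-1-yl)amino on a saturated ring carbon. Among the compounds with values here, no pair of measured compounds here differs in this way, so there is no measured step to lean on. With the group simply lengthened and its donor and acceptor count unchanged, the author expects at most a modest rise in this assay, near the edge of the scatter, estimated as a 1.5-fold higher number from compound 2 to compound 3 (0.16 log units; within the scatter). For compound 3 the estimated value in this assay is 13 nM, with a range from 4 nM to 40 nM.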

Compound 3, half-maximal inhibitory concentration: 1.1 nM
The estimate for compound 3 lay 12-fold (1.07 log units) above the measured number; the measured number lies below the stated range.
By their numbers in this assay, from the lowest: compounds 3 and 1 (each within the scatter of the next); then compound 2.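

Placing a methyl unit between the saturated ring carbon and the amine, so that ((2,3-dihydro-1H-inden-1-yl)amino)methyl replaces (2,3-dihydro-1H-inden-1-yl)amino, changes the result in this assay by an 8.1-fold lower number from compound 2 to compound 3 (0.91 log units; beyond the scatter). This shows that the position three ring bonds from the ring nitrogen tolerates a longer group and that the read-out responds clearly to this single change, even though the hydrogen-bond donor and acceptor counts stay the same. Nothing available here explains the shift.

The compounds shown leave open whether a longer chain, such as ((2,3-dihydro-1H-inden-1-yl)amino)ethyl, would move the number further in the same direction. They also leave open whether the same lengthening would have a similar effect with a simple benzylamino group in place of the 2,3-dihydro-1H-inden-1-yl unit.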